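The source may hold more compounds than are shown below. What is called first, only, known or untested is meant among the compounds shown, and "the series" means these compounds.

Compound 1 `O=C(N/N=C/c1c(-c2cc3ccccc3oc2=O)[nH]c2ccccc12)c1ccccc1` is the reference. In a toxicity assay on Vero cells (Chlorocebus sabaeus) for inhibition, read by MTT assay, with a stated time of 48 h (a lower number here means a stronger inhibitor, a higher number a weaker inhibitor), compound 1 gives 121000 nM. Compound 2 `O=C(N/N=C/c1c(-c2cc3ccccc3oc2=O)[nH]c2ccccc12)c1ccccc1Cl` carries chloro in place of hydrogen on an aromatic carbon. In this assay compound 2 reaches only a limit, > 200000 nM. Compound 3 `O=C(N/N=C/c1c(-c2cc3ccc(Br)cc3oc2=O)[nH]c2ccccc12)c1ccccc1` differs from compound 1 in its core by bromo in place of hydrogen on an aromatic carbon. In this assay compound 3 likewise reaches only a limit, > 200000 nM. The measured steps are an at least 1.6-fold higher number from compound 1 to compound 2 (0.21 log units; that floor lies within the scatter) and an at least 1.6-fold higher number from compound 1 to compound 3 (0.21 log units; that floor lies within the scatter), both resting on (the limit of > 200000 nM in this assay, at which 2 of the 3 values shown sit). Compound 4 `O=C(N/N=C/c1c(-c2cc3ccc(Br)cc3oc2=O)[nH]c2ccccc12)c1ccc(Cl)cc1` arises from compound 3 by chloro in place of hydrogen on an aromatic carbon. This is the same kind of change as from compound 1 to compound 2, yet the place differs: there the chloro sits ortho to a large group, here para to a large group. The step to compound 4 is expected to be a step that the limit leaves unreadable from compound 3 to compound 4 because the same kind of change gave an at least 1.6-fold higher number from compound 1 to compound 2 (0.21 log units; that floor lies within the scatter). For compound 4 the expected value is 260000 nM, estimated between 150000 nM and 600000 nM.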

Compound 4, half-maximal inhibitory concentration in the Vero assay: 71400 nM
Estimate against measurement, compound 4: 3.6-fold (0.56 log units) above; measured number outside the range, below it.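

In the Vero assay, chloro in place of hydrogen on the benzoyl ring gives an at least 2.8-fold lower number from compound 3 to compound 4 (0.44 log units; beyond the scatter), so this change does not carry over unchanged from one core to the other: the same change on two cores in the Vero assay, an at least 1.6-fold higher number (0.21 log units; that floor lies within the scatter) from compound 1 to compound 2 and an at least 2.8-fold lower number (0.44 log units; beyond the scatter) from compound 3 to compound 4, at least 4.6-fold (0.66 log units) apart, beyond the scatter of two such steps. The steps' comparison rests on a limit, and the chloro also sits at a different place in compound 2 and compound 4, so the effect of the core cannot be told apart from the effect of the place: the limit of > 200000 nM in the Vero assay, at which 2 of the 4 values shown sit. In a physicochemical assay for lipophilicity (on this read-out higher numbers stand for higher lipophilicity and lower numbers for lower lipophilicity), compound 3 gives 6.71 and compound 4 gives 7.48. Lipophilicity rises along the step to compound 4, but a single pair cannot tie that rise to the lower number: the measured partition coefficient of compound 3, 6.71, and of compound 4, 7.48, a number 0.77 log units higher (beyond the scatter).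

On these data alone, it remains open how a 4-chlorophenyl group would behave on the core of compound 1. As far as these compounds go, it is also open whether a methoxy group or an amine in that same place would shift the number in the same direction.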